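This account rests on a few compounds, and the source may have more. Where it says the series, first, only, none or still open, it means among the compounds named here.

Compound 1 `COc1ccc(C(=O)/C=C/c2ccc(Br)cc2)c2c1C=CC(C)(C)O2` carries a 4-bromophenyl on its double-bonded chain carbon. In a functional assay on SK-OV-3 cells (Homo sapiens) for antiproliferative activity, read by MTT assay, with a stated time of 24 h (a higher number here means a weaker inhibitor, a lower number a stronger inhibitor), compound 1 gives only a limit of the assay, > 10000 nM, and not a number. Compound 2 `COc1ccc(C(=O)/C=C/c2ccc(-n3ccnc3)cc2)c2c1C=CC(C)(C)O2` bears a 1H-imidazol-1-yl in place of bromo on an aromatic carbon, and in this assay compound 2 gives 7200 nM. The step of an at least 1.3-fold lower number from compound 1 to compound 2 (0.14 log units; that floor lies within the scatter) is the only measured one here, and its floor rests on (the limit of > 10000 nM in this assay, at which 1 of the 2 values shown sits). Compound 3 `COc1ccc(C(=O)/C=C/c2ccccc2Cl)c2c1C=CC(C)(C)O2` differs from compound 1 by 2-chlorophenyl in place of 4-bromophenyl on a double-bonded chain carbon bound to a double-bonded chain carbon. That swap of 2-chlorophenyl for 4-bromophenyl is not the change measured between compound 1 and compound 2, so the single measured step does not bear on it directly; it shows at most a small movement that stays within the scatter, and nothing among these compounds shows that exchanging one halogenated phenyl for another moves the number beyond the scatter. Compound 3 is therefore expected to sit close to the limit that compound 1 shows. The expected step is a step that the limit leaves unreadable from compound 1 to compound 3, which lies within the scatter. The estimate for compound 3 in this assay is 15000 nM, between 5000 nM and 40000 nM.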

Compound 3, half-maximal inhibitory concentration: > 10000 nM
Compound 3: a limit, no number; the forecaster's own chance of this, stated with the estimate: 65%; the middle value lies beyond the limit too.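

In this assay compound 3 gives > 10000 nM, which is a limit and not a number. Among the compounds shown here, compound 1 also gives only a limit, so no step between compound 1 and compound 3 can be read. The compounds shown leave open whether 2-chlorophenyl in place of 4-bromophenyl changes the read-out at all, and by how much: the limit of > 10000 nM in this assay, at which 2 of the 3 values shown sit.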